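Swapping the Triazole Substituent in a Thiocarbamate Series

The source may report more compounds than this note shows. Statements on the series, on what has been measured and on what is new or still open speak of the compounds shown alone.

Of the compounds shown here, two have been measured so far in a functional assay on MGC-803 cells (Homo sapiens) for inhibition, read by MTT assay, with a stated time of 72 h; on this read-out higher numbers stand for weaker inhibition and lower numbers for stronger inhibition. Compound 1 `COc1ccc(-n2cc(CSC(=S)N3CCN(C(=O)OC(C)(C)C)CC3)nn2)cc1` gives 87300 nM, the highest of the two numbers and therefore the weaker of the pair. Compound 2 `O=C(OCc1ccccc1)N1CCN(C(=S)SCc2cn(Cc3ccc(F)cc3)nn2)CC1` gives 17600 nM, a number far enough below that of compound 1 to lie beyond the scatter; compound 2 differs from compound 1 at more than one place, so the two values are only compared, not traced to a single change.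

Compound 3 `CC(C)(C)OC(=O)N1CCN(C(=S)SCc2cn(Cc3ccc(Cl)cc3)nn2)CC1` is unmeasured. It differs from compound 1 in one place: 4-chlorobenzyl in place of 4-methoxyphenyl on an aromatic nitrogen. Because compound 2, which also carries a benzyl group on that aromatic nitrogen, gives 17600 nM, compound 3 is expected to move toward stronger inhibition, with the step from compound 1 to compound 3 estimated at a 3.5-fold lower number from compound 1 to compound 3 (0.54 log units; beyond the scatter). Compound 3 is thus expected to give about 25000 nM in this assay, within a range from 8000 nM to 80000 nM.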

Compound 3, half-maximal inhibitory concentration: 9790 nM
Compound 3: middle estimate off by 2.6-fold (0.41 log units), on the high side; measured number inside the range.
By their numbers in this assay, from the lowest: compounds 3 and 2 (each within the scatter of the next); then compound 1.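

In this assay, replacing 4-methoxyphenyl with 4-chlorobenzyl on the aromatic nitrogen brings an 8.9-fold lower number from compound 1 to compound 3 (0.95 log units; beyond the scatter). Within the data shown here, this is the first reading tied to this one position, since the rest of the molecule stays the same, whereas the earlier pair differed at more than one place. The swap still changes two features together, a methoxy group becoming chlorine and a phenyl becoming a benzyl, and no measurement here accounts for the shift.

The compounds shown leave open which of those two features carries the step, a question that 4-methoxybenzyl or 4-chlorophenyl on the same nitrogen would separate. Also open, from the compounds shown here alone, is how the number would respond to a longer chain between that nitrogen and the ring, or to an amine in place of the chlorine.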